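Oxadiazole aryl swap: pyridin-4-yl to pyridin-2-yl

The source may hold more compounds than are shown below. What is called first, only, known or untested is meant among the compounds shown, and "the series" means these compounds.

Measured compounds:
compound 1, `N#Cc1ccc(-c2cnc3[nH]cc(-c4nnc(-c5ccc(F)cc5)o4)c(=O)c3c2)cc1`: 10.2%
compound 2, `CS(=O)(=O)c1ccc(-c2cnc3[nH]cc(-c4nnc(-c5ccncc5)o4)c(=O)c3c2)cc1`: 2.64%

Two compounds of the shared core have been run in a functional assay on HCT-116 cells (Homo sapiens) for inhibition, read by MTT assay, with a stated time of 24 h, tested at 2.5 uM; a higher number here means more inhibition of growth at the concentration tested, a lower number less inhibition of growth. Compound 1 gives 10.2%. Compound 2 gives 2.64%. Within the data shown here, compound 2 stands at the lower of the two numbers, but the gap to compound 1 lies within the usual scatter, so the two values cannot be told apart; no step between measured compounds is available to build on.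

Compound 3, `CS(=O)(=O)c1ccc(-c2cnc3[nH]cc(-c4nnc(-c5ccccn5)o4)c(=O)c3c2)cc1`, has not been run in this assay. It differs from compound 2 in one place: pyridin-2-yl in place of pyridin-4-yl on an aromatic carbon. The two compounds contain the same atoms, joined differently.

Among the measured compounds shown here, with both measured numbers sitting close together and no measured step to guide a direction, the expected move a number 2.4 percentage points higher from compound 2 to compound 3 (within the scatter) is none beyond the scatter. Compound 3 is therefore estimated at 5%, with a range from -5% to 16%, which leaves room for the change to be as small as the two known values suggest.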

Compound 3, percent growth inhibition at one concentration: 5.37%
Estimate against measurement, compound 3: 0.4 percentage points below; measured number inside the range.
By their numbers in this assay, from the lowest: compounds 2, 3 and 1 (each within the scatter of the next).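

In this assay, pyridin-2-yl in place of pyridin-4-yl, on the aromatic carbon of the five-membered aromatic ring with 2 nitrogen and 1 oxygen, gives a number 2.7 percentage points higher from compound 2 to compound 3 (within the scatter). Among these compounds, this is the first step that isolates this position: the two compounds contain the same atoms, so only the way the pyridine is joined changes, and at this single concentration that change leaves compound 2 and compound 3 indistinguishable. No measurement on hand bears on why the two pyridines read alike.

The compounds shown leave open whether this position responds to anything beyond a swap between pyridine isomers, since a single step within the scatter cannot separate a truly insensitive position from a read-out with too little signal to show a difference. Pyridin-3-yl would complete the isomer set in this place, while a carboxylic acid or a short chain ending in an amine on the same carbon would test a much larger change against the same methylsulfonylphenyl background.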